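Dropping One Trifluoromethyl Group: From Compound 3 to Compound 4

The source may report more compounds than this note shows. Statements on the series, on what has been measured and on what is new or still open speak of the compounds shown alone.

Of the compounds shown here, three of a shared core have been measured in a functional assay on UO-31 cells (Homo sapiens) for inhibition, read by sulforhodamine B assay, with a stated time of 48 h, tested at 10 uM; on this read-out higher numbers stand for a weaker effect at the one concentration tested and lower numbers for a stronger effect. Compound 1 `O=C(Nc1cccc(-n2cc(-c3ccncc3)c(-c3cc(O)cc(Cl)c3)n2)c1)Nc1ccc(Cl)c(Cl)c1` gives -41.3%. Compound 2 `COc1cc(Cl)cc(-c2nn(-c3cccc(NC(=O)Nc4ccc(Cl)c(C(F)(F)F)c4)c3)cc2-c2ccncc2)c1` gives 11.1%. Compound 3 `COc1cc(Cl)cc(-c2nn(-c3cccc(NC(=O)Nc4cc(C(F)(F)F)cc(C(F)(F)F)c4)c3)cc2-c2ccncc2)c1` gives -0.18%. On these numbers compound 3 stands second highest of the three; its nearest neighbour is compound 2, whose number lies higher by a gap that is beyond the scatter, and the furthest is compound 1, whose number lies much lower, also beyond the scatter.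

Compound 4 `COc1cc(Cl)cc(-c2nn(-c3cccc(NC(=O)Nc4cccc(C(F)(F)F)c4)c3)cc2-c2ccncc2)c1` has not yet been measured in this assay. It differs from compound 3 in one place: hydrogen in place of trifluoromethyl on an aromatic carbon. Among the measured compounds shown here, no step between two measured compounds of this set isolates such a change, so the expectation rests only on where compounds 2 and 3 sit. Both of them, each carrying a trifluoromethyl group on the terminal ring of the urea, lie close to one another, and the second group in compound 3 did not move the number far from compound 2. The author therefore expects the step from compound 3 to compound 4 to be a number 8.2 percentage points higher from compound 3 to compound 4 (within the scatter), that is, no change beyond the scatter, if anything a slightly higher number. Compound 4 is estimated at 8% in this assay, with a range from -15% to 30%.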

Compound 4, a percentage reported as activity, at one concentration (the size of the read-out at that concentration, not a potency): -4.59%
For compound 4 the middle estimate is 12.6 percentage points above the measured one; measured number inside the range.
By their numbers in this assay, from the lowest: compound 1; then compounds 4 and 3 (each within the scatter of the next); then compound 2.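

In this assay, compound 4 shows that a trifluoromethyl group on this aromatic carbon can give way to hydrogen without a change that can be told from the scatter (a number 4.4 percentage points lower from compound 3 to compound 4 (within the scatter)). Among the compounds shown here, this step isolates that change for the first time in the set, and it shows that keeping a second trifluoromethyl group on the ring is not needed to hold the read-out at this level. Compound 4 also gives a second single-place comparison, at another aromatic carbon of the same ring, where hydrogen in place of chloro does lead to a modest change beyond the scatter (a number 15.7 percentage points lower from compound 2 to compound 4 (beyond the scatter)), although nothing available here accounts for either step.

The compounds shown leave open what a methoxy group, an amine or a nitrile would do on either of these aromatic carbons, as only trifluoromethyl, chloro and hydrogen appear there. For the compounds shown here, no single-place pair sets the hydroxyl group of compound 1 against the methoxy group that compound 4 carries, so the effect of that exchange remains unresolved.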